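Swapping a Benzyloxy Arm for a Carboxymethoxyphenyl Group

The compounds below may be only part of what the source reports. "The series", "measured", "known", "first", "only" and "open" are said of these compounds alone.

Within the data shown here, compound 1 `COc1ccc(C(OCc2ccccc2)c2cccc3ccccc23)c(OC)c1OC` is the only compound here with a number rather than a limit: in a functional assay on MCF7 cells (Homo sapiens) for inhibition, read by sulforhodamine B assay, with a stated time of 48 h (a higher number here means a weaker inhibitor, a lower number a stronger inhibitor), compound 1 gives 14100 nM. Compound 2 `COc1ccc(/C(=N/OCC(=O)O)c2cccc3ccccc23)c(OC)c1OC` stops at the limit of this assay, > 20000 nM. Compound 3 `COc1cc(COC(c2ccc(OC)c(OC)c2OC)c2cccc3ccccc23)cc(OC)c1` also stops at the limit, > 20000 nM. The step of an at least 1.4-fold higher number from compound 1 to compound 3 (0.15 log units; that floor lies within the scatter) is therefore known only as a floor, set by the limit of > 20000 nM in this assay, at which 2 of the 3 values shown sit. Compound 4 `COc1ccc(C(c2ccc(OCC(=O)O)cc2)c2cccc3ccccc23)c(OC)c1OC` differs from compound 1 in one place: 4-(carboxymethoxy)phenyl in place of benzyloxy on a saturated chain carbon bound to two aromatic carbons. Among the measured compounds shown here, no measured step changes a group at this carbon, so the expectation rests on compound 1 already standing weak at 14100 nM. Compound 4 is expected to give about 25000 nM, between 8000 nM and 80000 nM, a step of a 1.8-fold higher number from compound 1 to compound 4 (0.25 log units; within the scatter) that would most likely end at the limit.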

Compound 4, half-maximal inhibitory concentration: > 20000 nM
Compound 4 was reported as a limit; the forecaster's own chance of this, stated with the estimate: 60%; the middle value lies beyond the limit too.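

Among these compounds, compound 4 gives the first reading of a change at this saturated chain carbon bound to two aromatic carbons, where 4-(carboxymethoxy)phenyl replaces benzyloxy. In this assay, from the compounds shown here alone, the step is an at least 1.4-fold higher number from compound 1 to compound 4 (0.15 log units; that floor lies within the scatter), so this swap brings no sign of a stronger inhibitor, while its true size stays unknown. Compound 4 gives a limit rather than a number, and the set now crowds against it: the limit of > 20000 nM in this assay, at which 3 of the 4 values shown sit.

Going by these compounds, whether a methyl ester of that acid, or an amine in its place, would give a measurable number at this carbon stays open.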